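Chloro to Bromo on a Shared Core: An Expected Step

This account rests on a few compounds, and the source may have more. Where it says the series, first, only, none or still open, it means among the compounds named here.

Compound 1 `Clc1ccc(Cn2cc(COc3ccc(Cl)cc3)nn2)cc1` gives 26.1 ug/mL in a physicochemical assay, read by spectrophotometry, with a stated time of 30 min; on this read-out higher numbers stand for weaker inhibition and lower numbers for stronger inhibition.
Compound 2 `Clc1ccc(OCc2cn(Cc3ccc(Br)cc3)nn2)cc1` gives 11 ug/mL in this assay.
Compound 3 `Cc1cc(OCc2cn(Cc3ccc(Cl)cc3)nn2)ccc1Cl` gives 11.4 ug/mL in this assay.

Compound 2 is reached from compound 1 by bromo in place of chloro on an aromatic carbon, and this brings a 2.4-fold lower number from compound 1 to compound 2 (0.38 log units; beyond the scatter). Compound 3 is reached from compound 1 by methyl in place of hydrogen on an aromatic carbon, and this brings a 2.3-fold lower number from compound 1 to compound 3 (0.36 log units; beyond the scatter). Compound 2 and compound 3 lie within the scatter of each other in this assay, so no order between them can be read.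

Compound 4 `Cc1cc(OCc2cn(Cc3ccc(Br)cc3)nn2)ccc1Cl`, not yet measured, differs from compound 3 by bromo in place of chloro on an aromatic carbon. This is the same change as the one from compound 1 to compound 2, made on a core that differs by the methyl described above, and it occurs twice among these compounds. Since the earlier change gave a 2.4-fold lower number from compound 1 to compound 2 (0.38 log units; beyond the scatter), a step of similar size is expected here, so that compound 4 is estimated at a 2.1-fold lower number from compound 3 to compound 4 (0.32 log units; beyond the scatter). Compound 4 is thus expected to give about 5.5 ug/mL in this assay, most likely between 2.5 ug/mL and 12 ug/mL; this rests on a single earlier pair, so it is uncertain.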

Compound 4, half-maximal inhibitory concentration: 16.5 ug/mL
Beside the measured number, compound 4's estimate is 3.0-fold (0.48 log units) below it; measured number above the stated range.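

In this assay the same swap of chloro for bromo, made on the core that carries the methyl, gives a 1.4-fold higher number from compound 3 to compound 4 (0.16 log units; within the scatter) and so cannot be told apart from repeat-measurement noise, whereas on the core of compound 1 it gave a 2.4-fold lower number from compound 1 to compound 2 (0.38 log units; beyond the scatter) and stood clear of that noise. The methyl shows the same picture, for on the bromo compounds it gives a 1.5-fold higher number from compound 2 to compound 4 (0.18 log units; within the scatter) while on the chloro compounds it gave a 2.3-fold lower number from compound 1 to compound 3 (0.36 log units; beyond the scatter) and could be read. So a step seen on one core did not carry over to a closely related core here, but two pairs cannot show how the step would behave in general, and nothing at hand explains why the two cores differ.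

Still open, as far as these compounds go, is whether the 4-chlorophenyl to 4-bromophenyl change would read clearly on any further core. Also open, from the compounds shown here alone, is what other groups at that aromatic carbon, such as fluoro, methoxy or a carboxylic acid, would do to the number.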